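The source may hold more compounds than are shown below. What is called first, only, known or untested is meant among the compounds shown, and "the series" means these compounds.

Working notes on the series. In an ADME assay for permeability, using PAMPA, with a stated time of 10 h, tested at 100 ug/mL (a lower number here means that the compound crosses the layer more slowly, a higher number that the compound crosses the layer faster), compound 1 `Oc1ccc(-c2cc3cccc(O)c3o2)c2cccnc12` gives 14.5 10^-6 cm/s. Compound 2 `Oc1c(Cl)cc(-c2cc3ccccc3o2)c2cccnc12` gives 2.6 10^-6 cm/s, the lower of the two numbers, and its gap to compound 1 lies beyond the scatter. Only these two readings exist so far, so compound 2 stands at the bottom of a very short scale.

The next compound is compound 3 `Oc1c(Cl)cc(-c2cc3cccc(O)c3o2)c2cccnc12`. It carries hydroxy in place of hydrogen on an aromatic carbon of compound 2, on a six-membered aromatic ring of carbon only, part of a fused or bridged system of two rings: hydroxy in place of hydrogen on an aromatic carbon.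

Within the data shown here, no measured pair differs in this one place, so the size of the step in this assay cannot be read from the data. Compound 1 also carries this hydroxy and reads 14.5 10^-6 cm/s, which leaves room for a rise, but that comparison does not isolate the change. A step within the scatter is expected, with a slight lean upward. The estimated step of a 1.5-fold higher number from compound 2 to compound 3 (0.16 log units; within the scatter) is therefore small. For compound 3 the expected value is 3.8 10^-6 cm/s, with an estimated range of 1.3 10^-6 cm/s to 11 10^-6 cm/s.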

Compound 3, apparent permeability: 16.4 10^-6 cm/s
Estimate against measurement, compound 3: 4.3-fold (0.64 log units) below; the whole stated range lies below it.
By their numbers in this assay, from the lowest: compound 2; then compounds 1 and 3 (each within the scatter of the next).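

In this assay, among these compounds, hydroxy in place of hydrogen on an aromatic carbon of the six-membered aromatic ring of carbon only gives the first readable step at this position: a 6.3-fold higher number from compound 2 to compound 3 (0.80 log units; beyond the scatter), a change beyond the scatter with chloro present on the other side of the molecule. Among the compounds shown here, the second pair, which differs only in the chloro, gives a 1.1-fold higher number from compound 1 to compound 3 (0.05 log units; within the scatter), which lies within the scatter, so with this hydroxy present compound 1 and compound 3 cannot be told apart, and the low reading of compound 2 goes with the absence of the hydroxy in the only pair that isolates it. The data at hand offer nothing that explains either step.

From the compounds shown here alone, the chloro step is read only with the hydroxy present, so its size without that hydroxy stays open. Also open, going by these compounds, is whether another group in the same place, such as methoxy, an amine or a carboxylic acid, would give a step like that of hydroxy.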